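Adding an Amino Group to the Triazole of Compound 2

The source may report more compounds than this note shows. Statements on the series, on what has been measured and on what is new or still open speak of the compounds shown alone.

Compound 1 `CCC(C)(C)Cc1c[nH]c(CCc2ccc(-c3ccccc3OCC(=O)O)cc2)n1` gives 103 nM in an assay on isolated protein for binding affinity to Bombesin receptor subtype-3 (Homo sapiens); on this read-out lower numbers stand for stronger inhibition and higher numbers for weaker inhibition.
Compound 2 `CCC(C)(C)Cc1c[nH]c(CCc2ccc(-c3ccccc3OCc3ncn[nH]3)cc2)n1` gives 22 nM in this assay.

Within the data shown here, compound 2 has the lowest of the two numbers so far; compound 1 is one step away: a 4.7-fold lower number from compound 1 to compound 2 (0.67 log units; beyond the scatter). Compound 3 `CCC(C)(C)Cc1c[nH]c(CCc2ccc(-c3ccccc3OCc3nc(N)n[nH]3)cc2)n1` differs from compound 2 by amino in place of hydrogen on an aromatic carbon. Among the measured compounds shown here, no measured step concerns this change; the only step known, from compound 1 to compound 2, swaps the whole group at the end of the chain rather than decorating it. With nothing to point either way, the expected step is small: a 1.1-fold lower number from compound 2 to compound 3 (0.04 log units; within the scatter). Compound 3 is therefore estimated at 20 nM in this assay, with a likely range from 6 nM to 70 nM.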

Compound 3, half-maximal inhibitory concentration: 27 nM
The estimate for compound 3 lay 1.4-fold (0.13 log units) below the measured number; the measured number falls inside the stated range.
By their numbers in this assay, from the lowest: compounds 2 and 3 (each within the scatter of the next); then compound 1.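

Amino in place of hydrogen on the aromatic carbon between two ring nitrogen atoms gives no readable difference in this assay (a 1.2-fold higher number from compound 2 to compound 3 (0.09 log units; within the scatter)). This position therefore tolerates an amino group, and the amino-triazole still compares well with the carboxy group (a 3.8-fold lower number from compound 1 to compound 3 (0.58 log units; beyond the scatter)). Nothing measured here offers an explanation for these results.

As far as these compounds go, whether a methyl group or a larger dimethylamino group at this carbon would also leave the number within the scatter of compound 2 remains open.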